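From phenyl to 4-nitrophenyl in an antiproliferative series

This account rests on a few compounds, and the source may have more. Where it says the series, first, only, none or still open, it means among the compounds named here.

In a functional assay on SGC-7901 cells (Homo sapiens) for antiproliferative activity, read by MTT assay, with a stated time of 48 h (a higher number here means a weaker inhibitor, a lower number a stronger inhibitor), compound 1 (`CC(=O)N1N=C(c2ccccc2)CC1c1ccc2c(c1)OCCO2`) gives 50200 nM while compound 2 (`CC(=O)N1N=C(c2ccc(F)cc2)CC1c1ccc2c(c1)OCCO2`) gives 68400 nM and compound 3 (`CC(=O)N1N=C(c2ccc(Br)cc2)CC1c1ccc2c(c1)OCCO2`) gives 52300 nM and these three values lie within the scatter of one another. Compound 4 (`CC(=O)N1N=C(c2ccc([N+](=O)[O-])cc2)CC1c1ccc2c(c1)OCCO2`) has not yet been measured. Its difference from compound 1 (nitro in place of hydrogen on an aromatic carbon) is nitro in place of hydrogen on an aromatic carbon, para to a large group, so that phenyl becomes 4-nitrophenyl. Two measured steps also replace hydrogen on an aromatic carbon: fluoro gave a 1.4-fold higher number from compound 1 to compound 2 (0.13 log units; within the scatter) and bromo gave a 1.0-fold higher number from compound 1 to compound 3 (0.02 log units; within the scatter) in this series. Exchanging fluoro for bromo gave a 1.3-fold lower number from compound 2 to compound 3 (0.12 log units; within the scatter) and so none of the three steps moved the number beyond the scatter. For the measured compounds named here, no measured compound carries a nitro group, which means these steps guide the expectation only loosely. No step beyond the scatter is therefore expected in this assay and the estimated change is a 1.0-fold lower number from compound 1 to compound 4 (0.00 log units; within the scatter) at its middle. For compound 4 the estimate is 50000 nM with a range of 20000 nM to 120000 nM as the expected span of a measurement.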

Compound 4, half-maximal inhibitory concentration: 70100 nM
Compound 4: middle estimate off by 1.4-fold (0.15 log units), on the low side, and the stated range covers the measured number.
By their numbers in this assay, from the lowest: compounds 1, 3, 2 and 4 (each within the scatter of the next).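

In this assay, the place on the aromatic ring para to a large group now takes nitro, a group of three heavy atoms with two hydrogen-bond acceptors and no net charge, and the step is a 1.4-fold higher number from compound 1 to compound 4 (0.15 log units; within the scatter). The earlier compounds shown here tested only single halogen atoms at this place, so this step shows that a larger, multi-atom group can also enter there without leaving the scatter. The exchanges with those halogens, a 1.3-fold higher number from compound 3 to compound 4 (0.13 log units; within the scatter) and a 1.0-fold higher number from compound 2 to compound 4 (0.01 log units; within the scatter), stay within it as well, so all four compounds remain indistinguishable in this assay, and nothing available explains this insensitivity.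

The compounds shown leave open whether an amine or a carboxylic acid at the same place would produce a step beyond the scatter, since every group seen there so far has left the number unmoved. They also leave open whether a longer chain on another part of the shared core would change a number that has so far stayed within the scatter.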